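Swapping the aryl group on an oxadiazoline core

The compounds below may be only part of what the source reports. "The series", "measured", "known", "first", "only" and "open" are said of these compounds alone.

Of the compounds shown here, two sharing one core have been tested in an ADME assay on Vero cells (Chlorocebus sabaeus) for cytotoxicity, read by MTT assay, with a stated time of 72 h; on this read-out lower numbers stand for stronger inhibition and higher numbers for weaker inhibition. Compound 1 `CC(=O)N1N=C(c2ccc(-n3c(C)ccc3C)cc2)OC1c1cccc([N+](=O)[O-])c1` carries a 3-nitrophenyl on a saturated ring carbon and in this assay gives 188000 nM. Compound 2 `CC(=O)N1N=C(c2ccc(-n3c(C)ccc3C)cc2)OC1c1ccc(Br)cc1` carries a 4-bromophenyl at the same place and in this assay gives 195000 nM. Among the compounds with values here, of the two numbers so far, compound 2 sits at one end, yet the step of a 1.0-fold higher number from compound 1 to compound 2 (0.02 log units; within the scatter) shows that compound 1 lies within the scatter of it, so the two aryl groups cannot be told apart here.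

Compound 3 `CC(=O)N1N=C(c2ccc(-n3c(C)ccc3C)cc2)OC1c1ccccc1[N+](=O)[O-]` is the next variation: 2-nitrophenyl in place of 4-bromophenyl on a saturated ring carbon. Within the data shown here, the only step that bears on this change is a 1.0-fold higher number from compound 1 to compound 2 (0.02 log units; within the scatter), which exchanged one of these aryl groups for another without a shift beyond the scatter. Bringing a nitrophenyl back, now as 2-nitrophenyl, is therefore expected to leave the number essentially where it is, with no step beyond the scatter in this assay. For compound 3 the estimate is 190000 nM, expected to fall between 100000 nM and 360000 nM, which means an expected step of a 1.0-fold lower number from compound 2 to compound 3 (0.01 log units; within the scatter).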

Compound 3, half-maximal inhibitory concentration: 175000 nM
Estimate against measurement, compound 3: 1.1-fold (0.04 log units) above; measured number inside the range.
By their numbers in this assay, from the lowest: compounds 3, 1 and 2 (each within the scatter of the next).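

In this assay, the two nitrophenyl compounds can now be compared directly: replacing 3-nitrophenyl with 2-nitrophenyl gives a 1.1-fold lower number from compound 1 to compound 3 (0.03 log units; within the scatter), so moving the nitro group on this ring produces no change that can be distinguished from scatter. Replacing 4-bromophenyl with 2-nitrophenyl swaps a bromine for a nitro group that brings hydrogen-bond acceptors, which 4-bromophenyl lacks, yet the result is a 1.1-fold lower number from compound 2 to compound 3 (0.05 log units; within the scatter), again too small to separate the two compounds. All three aryl groups on this saturated ring carbon therefore lie within the scatter of one another, and no further data are available to explain why.

As far as these compounds go, all three compounds carry a substituted phenyl ring at this place, so it remains open whether a non-aromatic group such as cyclohexyl, or a phenyl bearing an amine or a carboxylic acid, would shift the number beyond the scatter. The acetyl group on the neighbouring ring atom is also the same throughout, leaving open what a longer chain in its place would do.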